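Moving the bromine to a 2-bromophenyl amine

The source may report more compounds than this note shows. Statements on the series, on what has been measured and on what is new or still open speak of the compounds shown alone.

Among the measured compounds shown here, compound 1 `COc1ccc(Nc2nc(-c3cccc(F)c3)nc3ccc(F)cc23)cc1` is the one compound with a number rather than a limit in a functional assay on MDA-MB-231 cells (Homo sapiens) for cytotoxicity, read by MTT assay, with a stated time of 48 h; on this read-out higher numbers stand for weaker inhibition and lower numbers for stronger inhibition: compound 1 gives 47300 nM. Compound 2 `Fc1ccc(Nc2nc(-c3cccc(F)c3)nc3ccc(F)cc23)cc1` reaches only a limit of the assay, > 50000 nM. Compound 3 `Fc1cccc(-c2nc(Nc3cccc(Br)c3)c3cc(F)ccc3n2)c1` likewise stops at a limit, > 50000 nM. Both steps, an at least 1.0-fold higher number from compound 1 to compound 2 (0.02 log units; that floor lies within the scatter) and an at least 1.0-fold higher number from compound 1 to compound 3 (0.02 log units; that floor lies within the scatter), run into the same floor (the limit of > 50000 nM in this assay, at which 2 of the 3 values shown sit), so their true size stays hidden. Compound 4 `Fc1cccc(-c2nc(Nc3ccccc3Br)c3cc(F)ccc3n2)c1` differs from compound 1 by 2-bromophenyl in place of 4-methoxyphenyl on a nitrogen on an aromatic ring. The closest measured comparison, with 3-bromophenyl entering, gave no readable step, so the expected step of a 1.2-fold higher number from compound 1 to compound 4 (0.07 log units; within the scatter) is small or again masked by the limit. Compound 4 is therefore estimated at 55000 nM, spanning 20000 nM to 150000 nM, most likely reported only as a limit.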

Compound 4, half-maximal inhibitory concentration: > 50000 nM
Compound 4 ended at the assay's limit (the forecaster's own chance of this, stated with the estimate: 70%); the middle value lies beyond the limit too.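

The change to 2-bromophenyl gives an at least 1.0-fold higher number from compound 1 to compound 4 (0.02 log units; that floor lies within the scatter), so a third group on this nitrogen ends at the same floor in this assay. The steps from compound 2 and compound 3 to compound 4 cannot be read, which leaves 2-bromophenyl and 3-bromophenyl unranked. Compound 1 remains the only compound with a number, and the comparison stops at one limit: the limit of > 50000 nM in this assay, at which 3 of the 4 values shown sit.

From the compounds shown here alone, how far compound 2, compound 3 and compound 4 truly lie past that limit stays open. Also open, going by these compounds, is whether a hydroxyl or a dimethylamino group on this phenyl ring would give a readable value.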